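Removing a Ring Methyl in a Low-Solubility Series

The compounds below may be only part of what the source reports. "The series", "measured", "known", "first", "only" and "open" are said of these compounds alone.

The measured compounds:
Compound 1 `CN1CCN(c2ccc(/C=C3/SC(Nc4ccccc4Cl)=NC3=O)cc2)CC1` gives 0.43 ug/mL in a physicochemical assay (Homo sapiens) for solubility, with a stated time of 18 h, at pH 7.4; on this read-out higher numbers stand for higher solubility and lower numbers for lower solubility.
Compound 2 `O=C1N=C(Nc2ccccc2Cl)S/C1=C/c1ccc(N2CCNCC2)cc1` gives 0.14 ug/mL in this assay.
Compound 3 `CN1CCN(c2ccc(/C=C3/SC(Nc4ccc(Oc5ccccc5)cc4)=NC3=O)cc2)CC1` gives 0.1 ug/mL in this assay.

All three numbers are small, so none of these compounds dissolves readily. Compound 1 and compound 2 share a core and differ by one change, (hydrogen in place of methyl on an amine nitrogen in a ring). That change made the step of a 3.1-fold lower number from compound 1 to compound 2 (0.49 log units; beyond the scatter). Compound 3 is built on a different core; the difference between the two cores is not broken down here, and compound 3 and compound 2 give numbers within the scatter of each other.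

Compound 4 `O=C1N=C(Nc2ccc(Oc3ccccc3)cc2)S/C1=C/c1ccc(N2CCNCC2)cc1` has not been measured. It comes from compound 3 by hydrogen in place of methyl on an amine nitrogen in a ring, the same change that turned compound 1 into compound 2. The expectation for compound 4 rests on that earlier step: a similar move is estimated, a 2.5-fold lower number from compound 3 to compound 4 (0.40 log units; beyond the scatter), because compound 3 sits at 0.1 ug/mL and the matching change on compound 1 gave a 3.1-fold lower number from compound 1 to compound 2 (0.49 log units; beyond the scatter). Compound 4 is therefore expected to give about 0.04 ug/mL, likely between 0.01 ug/mL and 0.15 ug/mL, with a real chance that so low a value is reported only as a limit.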

Compound 4, solubility: 0.1 ug/mL
For compound 4 the middle estimate is 2.5-fold (0.40 log units) below the measured one; low and high end bracket the measured number.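

In this assay, putting hydrogen in place of methyl on the amine nitrogen of the ring gives no change at the digits printed from compound 3 to compound 4 (within the scatter), whereas on the core of compound 1 the same change gave a 3.1-fold lower number from compound 1 to compound 2 (0.49 log units; beyond the scatter). The step seen on one core therefore did not repeat beyond the scatter on the other, but a single pair on each core gives no general rule and does not show that the change can never matter on the core of compound 3. Nothing available here bears on why the two pairs differ.

The compounds shown leave open how the number would respond to an ethyl group, a longer chain or a carboxylic acid on that ring nitrogen in place of methyl or hydrogen. Also open, as far as these compounds go, is whether, on a third core, 4-methylpiperazin-1-yl to piperazin-1-yl would follow the step from the first pair or the one from the second.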